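Removing the aryl group from the core amine of compound 1

A few compounds are considered here, and "the series" means these few. Any claim that something is new, unique, unknown or untested is made for them only; others in the source may bear on it.

Measured compounds:
compound 1 `Cc1ccc(Nc2nccc(-c3ccnc4ccccc34)n2)cc1`: 100%
compound 2 `FC(F)(F)c1ccc(Nc2nccc(-c3cnc4ccccc4c3)n2)cc1`: 35.4%

Of the compounds shown here, two have been tested in a functional assay on SK-LU-1 cells (Homo sapiens) for cytotoxicity, read by sulforhodamine B assay, with a stated time of 48 h, tested at 50 uM; on this read-out lower numbers stand for less inhibition and higher numbers for more inhibition at the one concentration tested (going by the name of the read-out). Compound 1 gives 100%, the highest of the two numbers; compound 2 gives 35.4%, a number that lies well beyond the scatter below that of compound 1. The two differ in more than one place, so no single step can be read from them.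

Compound 3 `Nc1nccc(-c2ccnc3ccccc23)n1` has not yet been measured. Going by the values given here, it shares its core with compound 1, and the single change between them is this: hydrogen in place of 4-methylphenyl on a nitrogen on an aromatic ring. The nitrogen that carried the 4-methylphenyl group in compound 1 thus carries only hydrogen in compound 3.

Among the compounds with values here, nothing measured so far shows what this nitrogen substituent contributes, so the expectation rests on the size of compound 1's read-out alone. Compound 3 is expected to inhibit less than compound 1, with a step of a number 70 percentage points lower from compound 1 to compound 3 (beyond the scatter) that is expected to lie beyond the scatter. Compound 3 is estimated to give 30%, within a range of 5% to 65%.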

Compound 3, a percentage reported as inhibition, at one concentration (the size of the read-out at that concentration, not a potency): 78.2%
Beside the measured number, compound 3's estimate is 48.2 percentage points below it; the whole stated range lies below it.
By their numbers in this assay, from the lowest: compound 2; then compound 3; then compound 1.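

In this assay, going by these compounds alone, replacing 4-methylphenyl with hydrogen on this nitrogen on an aromatic ring gives a number 21.8 percentage points lower from compound 1 to compound 3 (beyond the scatter), the first single change that can be read. The step lies beyond the scatter but is modest, and compound 3 still gives 78.2%, so on this core and at this one concentration, most of the read-out does not depend on the 4-methylphenyl group. The number is therefore only modestly lower once the whole aryl group is gone from the nitrogen, which the two earlier compounds, differing in more than one place, could not show, and no measurement available here explains the step.

The compounds shown leave open whether a small alkyl group such as methyl, a longer chain such as n-butyl, or an acetyl group on this nitrogen would give a number nearer to that of compound 1 or that of compound 3. They also leave open whether the methyl group of the 4-methylphenyl substituent has any part in the step, which an unsubstituted phenyl group on the same nitrogen would address.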